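A few compounds are considered here, and "the series" means these few. Any claim that something is new, unique, unknown or untested is made for them only; others in the source may bear on it.

Of the compounds shown here, three have so far been measured in an assay on cells for inhibition of ubiquitin carboxyl-terminal hydrolase isozyme L5 (Homo sapiens), read by fluorescence, with a stated time of 30 min; a lower number here means a stronger inhibitor, a higher number a weaker inhibitor. Compound 1 `CC(=O)Nc1cccc(-c2cn(Cc3cc(C(=O)O)cc(-c4ccccc4C(=O)O)c3)nn2)c1` gives 96200 nM, the second highest of the three numbers. Compound 2 `Nc1ccc(-c2cn(Cc3cccc(-c4ccccc4C(=O)O)c3)nn2)cc1` gives 116000 nM, and compound 3 `CC(C(=O)O)c1ccc(C(=O)c2cccc(-c3occc3C(=O)O)c2)s1` gives 75700 nM; both of these lie within the usual scatter of compound 1, so the three numbers cannot be separated from one another. For the measured compounds named here, no pair of measured compounds differs in a single place, so no measured step is available as a guide. The unmeasured compound 4 `NS(=O)(=O)Nc1ccc(-c2cn(Cc3cc(C(=O)O)cc(-c4ccccc4C(=O)O)c3)nn2)cc1` differs from compound 1 in one respect: 4-(sulfamoylamino)phenyl in place of 3-acetamidophenyl on an aromatic carbon. With nothing measured to lean on, this change is expected to shift the number by no more than the scatter, in no particular direction. Compound 4 is therefore estimated at 90000 nM, within a range from 30000 nM to 300000 nM, a step of a 1.1-fold lower number from compound 1 to compound 4 (0.03 log units; within the scatter).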

Compound 4, half-maximal inhibitory concentration: 84500 nM
The estimate for compound 4 lay 1.1-fold (0.03 log units) above the measured number; measured number inside the range.
By their numbers in this assay, from the lowest: compounds 3, 4, 1 and 2 (each within the scatter of the next).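

In this assay, for the compounds shown here, the first comparison that differs in one place, 4-(sulfamoylamino)phenyl in place of 3-acetamidophenyl on the five-membered ring, gives a 1.1-fold lower number from compound 1 to compound 4 (0.06 log units; within the scatter) and so cannot be told apart from no change. This position therefore carries either group with no readable difference in the number, even though the entering group brings sulfur and more hydrogen-bond donors. Nothing measured here offers an explanation for this result.

From the compounds shown here alone, since the group and its attachment point on the phenyl ring change together, their separate contributions stay unknown. Also open, going by these compounds, is whether a smaller group on that phenyl ring, such as a hydroxyl or a nitrile, would move the number beyond the scatter.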